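Swapping a side group for cyano on compound 2

A few compounds are considered here, and "the series" means these few. Any claim that something is new, unique, unknown or untested is made for them only; others in the source may bear on it.

In a functional assay on KB cells (Homo sapiens) for cytotoxicity, read by spectrophotometry and crystal violet staining (on this read-out lower numbers stand for stronger inhibition and higher numbers for weaker inhibition), compound 1 (`CC(=O)N/N=C/c1c(Cl)n(C2O[C@H](CO)[C@@H](O)[C@H]2O)c2cc(Cl)c(Cl)cc12`) gives 9000 nM and compound 2 (`COC(=N)c1c(Cl)n(C2O[C@H](CO)[C@@H](O)[C@H]2O)c2cc(Cl)c(Cl)cc12`) gives 50000 nM. Compound 2 therefore has the higher of the two exact numbers, making it the weaker inhibitor of this pair. Compound 3 (`OC[C@H]1O[C@@H](n2c(Br)nc3cc(Cl)c(Cl)cc32)[C@H](O)[C@@H]1O`) gives > 100000 nM, which is a limit of the assay and not a number.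

The next compound is compound 4 (`N#Cc1c(Cl)n(C2O[C@H](CO)[C@@H](O)[C@H]2O)c2cc(Cl)c(Cl)cc12`). Its change from compound 2 is a group of 2 heavy atoms (1 carbon, 1 nitrogen; no ring) in place of a group of 4 heavy atoms (2 carbon, 1 nitrogen, 1 oxygen; no ring), on an aromatic carbon. The new cyano group sits on an aromatic carbon, next to the ring atom that bears a chloro group. Among the measured compounds shown here, only one measured step changes the group at this place: a 5.6-fold higher number from compound 1 to compound 2 (0.74 log units; beyond the scatter). That modest step is a single example, so its direction may not carry over, and no clear shift beyond the scatter is expected in this assay. The expected change is a 1.7-fold lower number from compound 2 to compound 4 (0.22 log units; within the scatter). For compound 4, the estimated value is 30000 nM, with an expected range from 5000 nM to 100000 nM.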

Compound 4, half-maximal inhibitory concentration: 65000 nM
The estimate for compound 4 lay 2.2-fold (0.34 log units) below the measured number; the range from low to high includes it.
By their numbers in this assay, from the lowest: compound 1; then compounds 2 and 4 (each within the scatter of the next). At a limit, above all of these: compound 3.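

In this assay, exchanging the group on this aromatic carbon for cyano gives a 1.3-fold higher number from compound 2 to compound 4 (0.11 log units; within the scatter), so a much smaller group that has no hydrogen-bond donor cannot be told apart from the group it replaces. The second comparison at the same carbon gives a 7.2-fold higher number from compound 1 to compound 4 (0.86 log units; beyond the scatter), so among these three compounds, only the largest group, the one on compound 1, stands apart with a lower number. Compound 3 carries a limit of the assay and not a number, and this shows where the assay's readings stop: the limit of > 100000 nM in this assay, at which 1 of the 4 values shown sits.

As far as these compounds go, it remains open whether an amine, a carboxylic acid or a longer chain on this carbon would give a lower number than compound 1. The compounds shown also cannot tell which feature of the group on compound 1 goes with its lower number.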